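Serum half-life of thymidine carbonate and ester prodrugs

A few compounds are considered here, and "the series" means these few. Any claim that something is new, unique, unknown or untested is made for them only; others in the source may bear on it.

Measured compounds in an ADME assay on the whole organism (serum) with Homo sapiens as the target; on this read-out higher numbers stand for a longer-lived compound and lower numbers for a shorter-lived compound:
compound 1 `Cc1cn(C2CC(N=[N+]=[N-])C(COC(=O)CCCC(=O)OC(C)(C)C)O2)c(=O)[nH]c1=O` gives 0.55 h
compound 2 `CCCCOC(=O)OCC1OC(n2cc(C)c(=O)[nH]c2=O)CC1N=[N+]=[N-]` gives 0.15 h
compound 3 `Cc1cn(C2CC(N=[N+]=[N-])C(COC(=O)OCCO)O2)c(=O)[nH]c1=O` gives < 0.0167 h

Compound 3 stands at the bottom of the three. Its value in this assay is a limit of the assay and not a number, at the limit of < 0.0167 h in this assay, at which 1 of the 3 values shown sits. The step of an at least 32-fold lower number from compound 1 to compound 3 (1.51 log units; beyond the scatter) and the step of an at least 8.9-fold lower number from compound 2 to compound 3 (0.95 log units; beyond the scatter) both reach that limit, so the true gap may be wider than either states.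

Compound 4 `Cc1cn(C2CC(N=[N+]=[N-])C(COC(=O)OCCCCCO)O2)c(=O)[nH]c1=O` is not yet measured in this assay. It differs from compound 3 by 3-hydroxypropyl in place of hydroxy on a saturated chain carbon, two bonds along the chain from an oxygen next to a carbonyl group. Among the compounds with values here, the one measured step that bears on this position is an at least 8.9-fold lower number from compound 2 to compound 3 (0.95 log units; beyond the scatter), where the hydroxy came in at the cost of the half-life. Compound 4 keeps a hydroxy but sets it on a 3-hydroxypropyl chain, so a partial return toward compound 2 is expected, a step of an at least 2.9-fold higher number from compound 3 to compound 4 (0.47 log units; beyond the scatter). For compound 4 the half-life in this assay is estimated at 0.05 h, within 0.0167 h to 0.15 h, with a fair chance that only a limit is reported again.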

Compound 4, half-life: 0.267 h
The estimate for compound 4 lay 5.3-fold (0.73 log units) below the measured number; measured number above the stated range.
By their numbers in this assay, from the lowest: compounds 2 and 4 (each within the scatter of the next); then compound 1. At a limit, below all of these: compound 3.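

In this assay, the hydroxy does not on its own hold the half-life down at this position: with (5-hydroxypentyl)oxy in place of 2-hydroxyethoxy on the carbonate, the result is an at least 15-fold higher number from compound 3 to compound 4 (1.20 log units; beyond the scatter), so the length of the chain carrying the hydroxy matters here. On these data alone, compound 3 remains a limit of the assay and not a number, so the full size of that step stays unknown: the limit of < 0.0167 h in this assay, at which 1 of the 4 values shown sits. With the hydroxy on the longer chain, the comparison with the butoxy carbonate gives a 1.8-fold higher number from compound 2 to compound 4 (0.25 log units; within the scatter), while the comparison with the 3-(tert-butoxycarbonyl)propyl ester gives a 2.1-fold lower number from compound 1 to compound 4 (0.31 log units; beyond the scatter).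

Only two hydroxy chain lengths are shown, so how the half-life changes at lengths between them remains open. Also open, as far as these compounds go, is whether a longer chain, or an amine or a carboxylic acid in place of the hydroxy, would follow the same course.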